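The source may hold more compounds than are shown below. What is called first, only, known or untested is meant among the compounds shown, and "the series" means these compounds.

Working notes on the series, read in a functional assay (aorta) with Rattus norvegicus as the target; a higher number here means that more compound is needed for the effect, a lower number that less compound is needed. Compound 1 (`COc1ccc(-c2nc(/N=C(\N)N(C)C)sc2-c2ccc(OC)cc2)cc1`) gives 4.8 uM, compound 2 (`COc1ccc(-c2nc(CN)sc2-c2ccc(OC)cc2)cc1`) gives 7.7 uM, and compound 3 (`COc1ccc(-c2nc(CNC(=O)NC(C)C)sc2-c2ccc(OC)cc2)cc1`) gives 5.7 uM. Compound 3 therefore stands within the scatter of both other compounds, and the three numbers show no order that can be relied on.

The next entry is compound 4 (`COc1ccc(-c2nc(C(=O)N(C)C)sc2-c2ccc(OC)cc2)cc1`), not yet measured. It carries dimethylcarbamoyl in place of ((isopropylcarbamoyl)amino)methyl on an aromatic carbon of the shared core, next to the ring nitrogen and next to the ring sulfur: dimethylcarbamoyl in place of ((isopropylcarbamoyl)amino)methyl on an aromatic carbon.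

Among the compounds with values here, three measured steps bear on this change, all made at the same place: a 1.6-fold higher number from compound 1 to compound 2 (0.21 log units; within the scatter), a 1.2-fold higher number from compound 1 to compound 3 (0.07 log units; within the scatter) and a 1.4-fold lower number from compound 2 to compound 3 (0.13 log units; within the scatter). None of them goes beyond the scatter, and no compound among these three goes against that. Within the data shown here, no measured compound carries dimethylcarbamoyl, however, so the expectation is an extrapolation and the range is kept wide. On these three steps, no change beyond the scatter is expected in this assay. The expected step is a 1.1-fold higher number from compound 3 to compound 4 (0.02 log units; within the scatter). The estimate for compound 4 is 6 uM, with an expected range from 2.5 uM to 15 uM.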

Compound 4, concentration for half-maximal effect: 3 uM
Beside the measured number, compound 4's estimate is 2.0-fold (0.30 log units) above it; the measured number falls inside the stated range.
By their numbers in this assay, from the lowest: compounds 4, 1, 3 and 2 (each within the scatter of the next, the first and the last beyond it).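

In this assay the series now shows its first step at this position beyond the scatter: a 2.6-fold lower number from compound 2 to compound 4 (0.41 log units; beyond the scatter) is modest, and it comes with dimethylcarbamoyl in place of aminomethyl on the same aromatic carbon. The other two new steps, a 1.9-fold lower number from compound 3 to compound 4 (0.28 log units; within the scatter) and a 1.6-fold lower number from compound 1 to compound 4 (0.20 log units; within the scatter), stay within the scatter, so compound 4 cannot be ordered against compound 3 or compound 1, and replacing ((isopropylcarbamoyl)amino)methyl, with its 2 hydrogen-bond donors, by dimethylcarbamoyl, with 0, does not move the number by more than the scatter. No measurement on these compounds accounts for the separation of compound 4 from compound 2.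

The compounds shown leave open whether the separation belongs to the carbonyl attached directly to the ring or to the two methyl groups on the amide nitrogen, which a primary carboxamide or an N-methyl carboxamide at this position would help to separate. They also leave open how a carboxylic acid, a longer chain on the amide nitrogen, or a group other than 4-methoxyphenyl on the two neighbouring ring atoms would read in this assay.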